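The source may report more compounds than this note shows. Statements on the series, on what has been measured and on what is new or still open speak of the compounds shown alone.

Compound 1 `O=C1c2ccccc2N(Cc2ccccc2)S(=O)(=O)N1COCc1ccccc1` and compound 2 `O=C1c2ccccc2N(Cc2cccc(Cl)c2)S(=O)(=O)N1Cc1ccccc1` share one core and differ from each other in two places at once, so no single step can be read between them. In a functional assay on HEL cells (Homo sapiens) for inhibition (on this read-out higher numbers stand for lower toxicity in this test and lower numbers for higher toxicity in this test), compound 1 gives > 98000 nM, which is a limit of the assay and not a number. In this assay compound 2 gives > 200000 nM, again a limit rather than a number. Compound 2 therefore stands at the limit of > 200000 nM in this assay, at which 1 of the 2 values shown sits, in this assay. Compound 1 sits at the limit of > 98000 nM in this assay, at which 1 of the 2 values shown sits, in this assay. Compound 3 `C#CCOCN1c2ccccc2C(=O)N(Cc2ccccc2)S1(=O)=O` has not yet been measured. It differs from compound 2 by propargyloxy in place of 3-chlorophenyl on a saturated chain carbon bound to a sulfonamide nitrogen in a ring. Going by the values given here, with both measured compounds resting at limits, no measured step shows how large such a change can be. The expected step is an at least 1.3-fold lower number from compound 2 to compound 3 (0.12 log units; that floor lies within the scatter) in this assay, that is none beyond the scatter. Compound 3 is therefore estimated at about 150000 nM in this assay, expected to fall between 50000 nM and 300000 nM, and most likely reported only as a limit.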

Compound 3, half-maximal cytotoxic concentration: > 140000 nM
Compound 3: no number, only a limit (the forecaster's own chance of this, stated with the estimate: 80%); the middle value does not contradict the limit.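

Compound 2 and compound 3 both give only limits in this assay, and the size of the step between them cannot be read. The compounds shown leave open at what concentration any of them becomes toxic to these cells, and whether propargyloxy in place of 3-chlorophenyl changes that.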